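The source may hold more compounds than are shown below. What is called first, only, known or untested is meant among the compounds shown, and "the series" means these compounds.

Series notes. The shared core is fixed throughout; only the group on the carbonyl carbon changes. Compound 1 `O=C(NC1CCC(=Cc2cccc(Oc3ccc(C(F)(F)F)cn3)c2)CC1)c1cccnc1` gives 27.8 nM in an assay for inhibition of Fatty-acid amide hydrolase 1 (Rattus norvegicus), read by fluorescence, with stated times of 1 min and 50 min; a lower number here means a stronger inhibitor, a higher number a weaker inhibitor. Compound 2 `O=C(NC1CCC(=Cc2cccc(Oc3ccc(C(F)(F)F)cn3)c2)CC1)c1cc[nH]n1` gives 266 nM in this assay, and compound 3 `O=C(NC1CCC(=Cc2cccc(Oc3ccc(C(F)(F)F)cn3)c2)CC1)c1cn[nH]c1` gives 64.6 nM. Among the three measured numbers compound 3 stands second highest: compound 1 is its nearest neighbour, compound 2 its furthest. The steps between them are a 9.6-fold higher number from compound 1 to compound 2 (0.98 log units; beyond the scatter), a 2.3-fold higher number from compound 1 to compound 3 (0.37 log units; beyond the scatter) and a 4.1-fold lower number from compound 2 to compound 3 (0.61 log units; beyond the scatter), all modest and all beyond the scatter.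

The next compound, compound 4 `O=C(NC1CCC(=Cc2cccc(Oc3ccc(C(F)(F)F)cn3)c2)CC1)c1ccc(-n2cccn2)nc1`, differs from compound 3 in one place: 6-(1H-pyrazol-1-yl)pyridin-3-yl in place of 1H-pyrazol-4-yl on a carbonyl carbon. The step bearing most directly on this is a 2.3-fold higher number from compound 1 to compound 3 (0.37 log units; beyond the scatter), since compound 4 again carries a pyridin-3-yl on the carbonyl carbon, now extended by a 1H-pyrazol-1-yl group. Moving back from a five-membered azole to the six-membered pyridine is therefore expected to bring a modest fall in this assay, with the added group itself an unknown in this set. The expected step is a 2.6-fold lower number from compound 3 to compound 4 (0.41 log units; beyond the scatter), putting compound 4 at an estimated 25 nM, within a range of 8 nM to 80 nM.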

Compound 4, half-maximal inhibitory concentration: 6.6 nM
The estimate for compound 4 lay 3.8-fold (0.58 log units) above the measured number; measured number outside the range, below it.
By their numbers in this assay, from the lowest: compound 4; then compound 1; then compound 3; then compound 2.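

Adding 1H-pyrazol-1-yl in place of hydrogen on an aromatic carbon of the pyridin-3-yl group gives a 4.2-fold lower number from compound 1 to compound 4 (0.62 log units; beyond the scatter) in this assay, so the group on the carbonyl carbon can grow beyond a single ring and the number still falls, which the single-ring groups could not show. Among these compounds, measured against the pyrazole groups, the two-ring 6-(1H-pyrazol-1-yl)pyridin-3-yl gives a 9.8-fold lower number from compound 3 to compound 4 (0.99 log units; beyond the scatter) and a 40-fold lower number from compound 2 to compound 4 (1.61 log units; beyond the scatter), the second being the only large step, and compound 4 now has the lowest number of the four, with all its steps beyond the scatter. Nothing available here accounts for this gain.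

From the compounds shown here alone, it remains open whether the gain requires 1H-pyrazol-1-yl itself or would also come with another group on the same aromatic carbon, such as a morpholine, an amine or a short alkyl chain. Also open, going by these compounds, is whether the pyridine nitrogen is needed, which a phenyl ring carrying the same 1H-pyrazol-1-yl group would test.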